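A few compounds are considered here, and "the series" means these few. Any claim that something is new, unique, unknown or untested is made for them only; others in the source may bear on it.

Working notes on the series, taken at the step from compound 3 to compound 4.

Compound 3 `N#C/N=C(/NCCCCc1c[nH]cn1)NCCCc1ccccn1` gives 5.48 in an in vitro functional assay on Sf9 cells for antagonist activity at histamine H2 receptor (Homo sapiens) (on this read-out higher numbers stand for higher potency (the scale is a negative logarithm) and lower numbers for lower potency), the higher of the two numbers in hand, although its neighbour compound 1 `N#C/N=C(/NCCCCc1c[nH]cn1)NCCCc1ccccc1` gives 5.25 and the step of a number 0.23 log units higher from compound 1 to compound 3 (within the scatter) stays inside the scatter. Compound 2 `N#C/N=C(/NCCCCc1c[nH]cn1)NCCCC1CCCCC1` reaches only a limit, < 5, in this assay (the limit of < 5 in this assay, at which 1 of the 3 values shown sits). From that limit the step of a number at least 0.48 log units higher from compound 2 to compound 3 (beyond the scatter) is the one movement in the set that goes beyond the scatter, while a number at least 0.25 log units lower from compound 1 to compound 2 (that floor lies within the scatter) cannot be sized.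

Compound 4 `N#C/N=C(/NCCCCc1c[nH]cn1)NCCCc1cccnc1` differs from compound 3 by pyridin-3-yl in place of pyridin-2-yl on a saturated chain carbon, three bonds along the chain from an amine nitrogen. Going by the values given here, no measured step swaps one pyridyl ring for another; the nearest guide is that phenyl to pyridin-2-yl, a number 0.23 log units higher from compound 1 to compound 3 (within the scatter), moved nothing beyond the scatter. The shift of the ring nitrogen is therefore expected to leave this assay about where compound 3 sits, a step of a number 0.18 log units lower from compound 3 to compound 4 (within the scatter) of no clear size. For compound 4 the estimate is 5.3, within 4.8 to 5.9.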

Compound 4, negative logarithm of the antagonist equilibrium constant: 5.92
The estimate for compound 4 lay 0.62 log units below the measured number; measured number outside the range, above it.
By their numbers in this assay, from the lowest: compounds 1 and 3 (each within the scatter of the next); then compound 4. At a limit, below all of these: compound 2.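

The position of the ring nitrogen matters at this site: moving from pyridin-2-yl to pyridin-3-yl gives a number 0.44 log units higher from compound 3 to compound 4 (beyond the scatter) in this assay, whereas the change from phenyl to pyridin-2-yl stayed within the scatter, and pyridin-3-yl is the only ring shown that clears phenyl, with a number 0.67 log units higher from compound 1 to compound 4 (beyond the scatter). Compound 2 remains a limit, so a number at least 0.92 log units higher from compound 2 to compound 4 (beyond the scatter) is a floor and not a size. Nothing at hand gives a cause for the gap between the two pyridyl rings.

Going by these compounds, it remains open how pyridin-4-yl, or a pyridin-3-yl ring carrying a methyl or a fluorine, would compare with compound 4. On these data alone, it is also open whether the step from pyridin-2-yl to pyridin-3-yl keeps its size on a shorter or a longer chain.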